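The compounds below may be only part of what the source reports. "The series", "measured", "known", "first", "only" and "open" are said of these compounds alone.

Measured compounds in a functional assay on the whole organism (Tail, strain ICR) with Mus musculus as the target, in the tail flick test, with a stated time of 90 min, at a dose of 25 umol/kg by the oral route; a lower number here means a weaker effect, a higher number a stronger effect of the compound at the dose given:
- compound 1, `O=C(O)[C@@H]1CCCN1C(=O)CN(c1nc(Cl)nc2[nH]cnc12)C1CC1`: 26%
- compound 2, `N=C(N)NCCC[C@H](NC(=O)CN(c1ncnc2c1ncn2C1CCCCO1)C1CC1)C(=O)OCc1ccccc1`: 61.6%
- compound 3, `C[C@@H](O)[C@H](NC(=O)CN(c1nc(Cl)nc2[nH]cnc12)C1CC1)C(=O)O`: 35.9%

Compound 3 stands second highest of the three numbers. Its nearest neighbour is compound 1, the step of a number 9.9 percentage points higher from compound 1 to compound 3 (within the scatter) being within the scatter, so the two are not separated. Going by the values given here, compound 2 is further off; no single-point step connects it to compound 3, and its value simply sits higher, beyond the scatter, on a different core.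

Compound 4, `C[C@H](NC(=O)CN(c1nc(Cl)nc2[nH]cnc12)C1CC1)C(=O)O`, is the next member and differs from compound 3 in one place: methyl in place of 1-hydroxyethyl on a saturated chain carbon bound to an amide-type nitrogen and a carbonyl carbon. Among the compounds with values here, the only measured step that touches this part of the molecule is the one from compound 1 to compound 3, which exchanged the whole amino-acid fragment on the carbonyl carbon and moved the read-out by a number 9.9 percentage points higher from compound 1 to compound 3 (within the scatter), within the scatter. The change to compound 4 is smaller than that exchange, so no step beyond the scatter is expected in this assay.

Compound 4 is therefore estimated at 31%, with a range from 16% to 48%. The expected step from compound 3 is a number 4.9 percentage points lower from compound 3 to compound 4 (within the scatter).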

Compound 4, a percentage reported as activity, at one dose (the size of the read-out at that dose, not a potency): 43.5%
Compound 4: the middle estimate sits 12.5 percentage points below what was measured; measured number inside the range.
By their numbers in this assay, from the lowest: compounds 1, 3 and 4 (each within the scatter of the next, the first and the last beyond it); then compound 2.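

In this assay, methyl in place of 1-hydroxyethyl on a saturated chain carbon bound to an amide-type nitrogen and a carbonyl carbon gives a number 7.6 percentage points higher from compound 3 to compound 4 (within the scatter), so this position keeps the read-out without the 1-hydroxyethyl group and its defined stereocentre. Going by these compounds alone, on the carbonyl carbon, (1-carboxyethyl)amino in place of 2-carboxypyrrolidin-1-yl gives a number 17.5 percentage points higher from compound 1 to compound 4 (beyond the scatter), the first step on the shared core to clear the scatter, whereas the exchange to (1-carboxy-2-hydroxypropyl)amino gave a number 9.9 percentage points higher from compound 1 to compound 3 (within the scatter). No evidence bears on the reason for either step.

Going by these compounds, whether a longer chain, a phenyl ring or an amine on this chain carbon would keep the read-out remains open. Also open, on these data alone, is whether these differences at one dose and one time reflect differences in potency.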